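Replacing tert-butyl with pyrrolidin-1-yl on a shared core

The compounds below may be only part of what the source reports. "The series", "measured", "known", "first", "only" and "open" are said of these compounds alone.

Compound 1 `COc1ncc(-c2nc(C(F)(F)F)sc2N2CCN(C(=O)Cn3nc(C)nc3C)[C@H](C)C2)cn1` gives 25 nM in a functional assay on CHO-K1 cells for antagonist activity at C-X-C chemokine receptor type 3 (Homo sapiens), read by FLIPR, with a stated time of 10 min; on this read-out higher numbers stand for weaker inhibition and lower numbers for stronger inhibition.
Compound 2 `CCCc1ncc(-c2nc(C(F)(F)F)sc2N2CCN(C(=O)Cn3nc(C)nc3C)[C@H](C)C2)cn1` gives 4.4 nM.
Compound 3 `Cc1nc(C)n(CC(=O)N2CCN(c3sc(C(F)(F)F)nc3-c3cnc(C(C)(C)C)nc3)C[C@H]2C)n1` gives 8.7 nM.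

Among these three, compound 3 stands second highest; its nearest neighbour is compound 2, where a 2.0-fold higher number from compound 2 to compound 3 (0.30 log units; within the scatter) lies within the scatter, while compound 1 lies furthest away, with a 2.9-fold lower number from compound 1 to compound 3 (0.46 log units; beyond the scatter). Compound 4 `Cc1nc(C)n(CC(=O)N2CCN(c3sc(C(F)(F)F)nc3-c3cnc(N4CCCC4)nc3)C[C@H]2C)n1` differs from compound 3 by pyrrolidin-1-yl in place of tert-butyl on an aromatic carbon. Within the data shown here, no measured step makes this exact exchange; the steps of a 5.7-fold lower number from compound 1 to compound 2 (0.75 log units; beyond the scatter) and a 2.9-fold lower number from compound 1 to compound 3 (0.46 log units; beyond the scatter) show only that swapping one group for another at this same aromatic carbon moved the numbers modestly. The step to compound 4 is therefore expected to be small, a 1.1-fold higher number from compound 3 to compound 4 (0.06 log units; within the scatter), with no firm direction. Compound 4 is estimated at 10 nM, within a range from 3 nM to 35 nM.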

Compound 4, half-maximal inhibitory concentration: 3.5 nM
Beside the measured number, compound 4's estimate is 2.9-fold (0.46 log units) above it; low and high end bracket the measured number.
By their numbers in this assay, from the lowest: compounds 4, 2 and 3 (each within the scatter of the next, the first and the last beyond it); then compound 1.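

Pyrrolidin-1-yl brings the first ring and the first ring-bound nitrogen to this aromatic carbon between two ring nitrogen atoms, and the change gives a 2.5-fold lower number from compound 3 to compound 4 (0.40 log units; beyond the scatter) and a 7.1-fold lower number from compound 1 to compound 4 (0.85 log units; beyond the scatter). Against propyl, the step is a 1.3-fold lower number from compound 2 to compound 4 (0.10 log units; within the scatter), so these two groups cannot be put in order. No available evidence explains these steps. The compounds shown leave open whether the ring or its nitrogen accounts for the step from tert-butyl. Cyclopentyl, dimethylamino or piperidin-1-yl at this carbon would separate these features.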